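A halogen swap on a compound at the limit

The compounds below may be only part of what the source reports. "The series", "measured", "known", "first", "only" and "open" are said of these compounds alone.

Of the compounds shown here, two have been tested in an ADME assay on MCF-10A cells (Homo sapiens) for inhibition, with a stated time of 48 h (a higher number here means a weaker inhibitor, a lower number a stronger inhibitor), compound 1 (`O=C(Nc1ccc(C(F)(F)F)cc1)N1CCC[C@H]1c1nc(-c2ccccc2)no1`) and compound 2 (`O=C(Nc1ccc(Cl)cc1)N1CCC[C@H]1c1nc(-c2cccc(Cl)c2)no1`), and neither has yielded a number. Compound 1 gives > 50000 nM in this assay and this is a limit of the assay. Compound 2 gives > 50000 nM in this assay and this too is a limit. Compound 2 therefore has no exact position, and its place on the numbers is the limit of > 50000 nM in this assay, at which 2 of the 2 values shown sit, in full.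

Compound 3 (`O=C(Nc1ccc(Cl)cc1)N1CCC[C@H]1c1nc(-c2ccc(I)cc2)no1`) has 4-iodophenyl in place of 3-chlorophenyl on an aromatic carbon. Going by the values given here, no step between measured compounds is available to size this change. In this assay no shift beyond the usual scatter is expected, and no direction is favoured. The expected size is a number no higher from compound 2 to compound 3 (the limit leaves the size open) and this is an estimate made against a limit rather than a number. The measurement may well return only a limit again. Compound 3 is estimated at 50000 nM with an expected range from 20000 nM to 100000 nM in this read-out.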

Compound 3, half-maximal inhibitory concentration: > 50000 nM
Compound 3: a limit, no number (the forecaster's own chance of this, stated with the estimate: 80%); the middle value lies on the limit itself.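

In this assay compound 3 gives > 50000 nM, which is a limit and not a number. With compound 2 also at a limit, no step can be read between compound 2 and compound 3. All the results shown stand at one place: the limit of > 50000 nM in this assay, at which 3 of the 3 values shown sit.

The compounds shown leave open what inhibitory concentration any of them has, and whether 4-iodophenyl and 3-chlorophenyl differ at all.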